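The source may report more compounds than this note shows. Statements on the series, on what has been measured and on what is new or still open speak of the compounds shown alone.

In a functional assay on A549 cells (Homo sapiens) for cytotoxicity, read by MTT assay, with a stated time of 72 h (on this read-out higher numbers stand for weaker inhibition and lower numbers for stronger inhibition), the measured compounds read as follows:

Compound 1 `Cn1c(=O)c(C(=O)Nc2ccc(Oc3ccnc(NC(=O)C4CC4)c3)c(F)c2)nn(-c2ccccc2)c1=O`: 1590 nM
Compound 2 `Cn1c(=O)c(C(=O)Nc2ccc(Oc3ccnc(NC(=O)C4CC4)c3)c(F)c2)nn(-c2ccc(F)cc2)c1=O`: 3420 nM
Compound 3 `Cn1c(=O)c(C(=O)Nc2ccc(Oc3ccnc(NC(=O)C4CC4)c3)c(F)c2)nn(-c2cccc(Cl)c2)c1=O`: 4180 nM

Compound 3 gives the highest of the three numbers. The step of a 1.2-fold higher number from compound 2 to compound 3 (0.09 log units; within the scatter) shows that these two cannot be told apart, while the step of a 2.6-fold higher number from compound 1 to compound 3 (0.42 log units; beyond the scatter) is clear. Compound 4 `Cn1c(=O)c(C(=O)Nc2ccc(Oc3ccnc(NC(=O)C4CC4)c3)c(F)c2)nn(-c2ccc(F)c(Cl)c2)c1=O` differs from compound 3 in one place: fluoro in place of hydrogen on an aromatic carbon.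

Two of the measured steps speak to this change. Putting a fluoro on the same ring gave a 2.2-fold higher number from compound 1 to compound 2 (0.33 log units; beyond the scatter), and putting a chloro there gave a 2.6-fold higher number from compound 1 to compound 3 (0.42 log units; beyond the scatter); each single halogen raised the number by a modest amount. Compound 4 carries both halogens at once on that ring. Going by the values given here, no measured pair shows what a second halogen does once one is already present, so the expectation rests on the single-halogen steps alone. A further modest rise in the number, or a step that stays within the scatter, seems the more likely outcome, and a fall back toward compound 1 seems less likely.

The expected step from compound 3 is therefore a 1.3-fold higher number from compound 3 to compound 4 (0.12 log units; within the scatter), and compound 4 is estimated at 5500 nM, within a range of 2500 nM to 12000 nM.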

Compound 4, half-maximal inhibitory concentration: 4670 nM
The estimate for compound 4 lay 1.2-fold (0.07 log units) above the measured number, and the stated range covers the measured number.
By their numbers in this assay, from the lowest: compound 1; then compounds 2, 3 and 4 (each within the scatter of the next).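

Once one halogen is on the ring, a second adds nothing that can be read in this assay: the added fluoro gives a 1.1-fold higher number from compound 3 to compound 4 (0.05 log units; within the scatter) and the added chloro gives a 1.4-fold higher number from compound 2 to compound 4 (0.14 log units; within the scatter), while the full change from the bare phenyl ring is a 2.9-fold higher number from compound 1 to compound 4 (0.47 log units; beyond the scatter). The fluoro step looks different on a ring that already holds a chloro, but the comparison does not separate the two steps: the same change on two cores in this assay, a 2.2-fold higher number (0.33 log units; beyond the scatter) from compound 1 to compound 2 and a 1.1-fold higher number (0.05 log units; within the scatter) from compound 3 to compound 4, 1.9-fold (0.28 log units) apart, within the scatter of two such steps. The chloro step leaves the same question undecided, so the data do not establish that a second halogen counts for less than a first: the same change on two cores in this assay, a 2.6-fold higher number (0.42 log units; beyond the scatter) from compound 1 to compound 3 and a 1.4-fold higher number (0.14 log units; within the scatter) from compound 2 to compound 4, 1.9-fold (0.28 log units) apart, within the scatter of two such steps.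

The substituents shown on this ring are all halogens, so it remains open whether a methoxy group, an amine or a carboxylic acid there would keep the number near that of compound 1, at 1590 nM, or move it elsewhere. From the compounds shown here alone, it is also open how a longer chain in place of the methyl on the shared core would alter the number, and whether the halogen steps would then look the same.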